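The compounds below may be only part of what the source reports. "The series", "measured", "known", "first", "only" and "open" are said of these compounds alone.

Working notes on a small set tested in a functional assay on HCT-15 cells (Homo sapiens) for inhibition, read by sulforhodamine B assay, with a stated time of 48 h, tested at 10 uM; a higher number here means a weaker effect of the compound at the concentration tested, a lower number a stronger effect. Among the measured compounds shown here, compound 1, `COc1cc(Cl)cc(-c2nn(-c3cccc(NC(=O)c4ccc(Cl)c(Cl)c4)c3)cc2-c2ccncc2)c1`, gives 57.9% in this assay, the highest of the two numbers available so far. Compound 2, `O=C(Nc1cccc(-n2cc(-c3ccncc3)c(-c3cc(O)cc(Cl)c3)n2)c1)Nc1ccc(Cl)c(C(F)(F)F)c1`, gives 5.79% in this assay; the gap between these two values lies well beyond the usual scatter, so compound 1 reads as the weaker of the two at the concentration tested.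

The next compound, compound 3, `COc1cc(Cl)cc(-c2nn(-c3cccc(NC(=O)Nc4ccc(Cl)c(C(F)(F)F)c4)c3)cc2-c2ccncc2)c1`, is not yet measured. Compared with compound 1 it differs at one place: (4-chloro-3-(trifluoromethyl)phenyl)amino in place of 3,4-dichlorophenyl on a carbonyl carbon. For the measured compounds named here, no measured pair carries this exact change, so the size of the step is open. The group that enters in compound 3 is also carried by compound 2, and compound 2 gives 5.79% in this assay; on that basis a sizeable step is expected, toward a lower number and beyond the scatter. The estimated step from compound 1 to compound 3 is a number 42.9 percentage points lower from compound 1 to compound 3 (beyond the scatter). For compound 3 the expected value in this assay is 15%, with a range from 3% to 40%.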

Compound 3, a percentage reported as activity, at one concentration (the size of the read-out at that concentration, not a potency): 7.28%
The estimate for compound 3 lay 7.7 percentage points above the measured number; the range from low to high includes it.
By their numbers in this assay, from the lowest: compounds 2 and 3 (each within the scatter of the next); then compound 1.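

In this assay, the change from 3,4-dichlorophenyl to (4-chloro-3-(trifluoromethyl)phenyl)amino on a carbonyl carbon gives a number 50.6 percentage points lower from compound 1 to compound 3 (beyond the scatter), so this position has a large effect on the read-out, which compounds 1 and 2 could not show because they differ in more than one place. The second single-place comparison, methyl in place of hydrogen on an oxygen on an aromatic ring, gives a number 1.5 percentage points higher from compound 2 to compound 3 (within the scatter), so with (4-chloro-3-(trifluoromethyl)phenyl)amino in place, this exchange on the oxygen has no readable effect. The large gap between compounds 1 and 2 therefore tracks the carbonyl-carbon change in this small set, not the hydrogen-to-methyl exchange on the oxygen. Nothing available explains the size of this step.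

Going by these compounds, the step swaps the whole group at once, so it remains open whether the amino nitrogen, the trifluoromethyl or the ring pattern carries it, and a nitrile in place of trifluoromethyl or a methyl on that nitrogen would help separate these. On these data alone, it is also open whether hydrogen and methyl on the oxygen remain equivalent when 3,4-dichlorophenyl stands on the carbonyl carbon.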